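Replacing a bromomethylphenyl amide with a pyridyl amide

This account rests on a few compounds, and the source may have more. Where it says the series, first, only, none or still open, it means among the compounds named here.

Compound 3 `COc1ccc2nc(C)cc(OCC(=O)Nc3ccc(Br)c(C)c3)c2c1` stands highest of the three measured compounds in a physicochemical assay for lipophilicity, read by HPLC, in phosphate buffer, measured as chromatographic lipophilicity, at pH 7.4 (on this read-out lower numbers stand for lower lipophilicity and higher numbers for higher lipophilicity), where compound 3 gives 5.95. Compound 1 `COc1ccc2nc(C)cc(OCC(=O)NCc3cc(C)cc(C)c3)c2c1` gives 5.25 and compound 2 `COc1cccc(NC(=O)COc2cc(C)nc3ccc(OC)cc23)c1` gives 4.49. The step of a number 1.46 log units higher from compound 2 to compound 3 (beyond the scatter) is large, and the step of a number 0.70 log units higher from compound 1 to compound 3 (beyond the scatter) is modest; the step of a number 0.76 log units lower from compound 1 to compound 2 (beyond the scatter) is modest in the other direction.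

Compound 4 `COc1ccc2nc(C)cc(OCC(=O)Nc3cccnc3)c2c1` differs from compound 3 in one place: pyridin-3-yl in place of 4-bromo-3-methylphenyl on an amide-type nitrogen. Among the compounds with values here, the steps that bear on it all concern exchanges of the group on the amide-type nitrogen. Moving from 4-bromo-3-methylphenyl to 3-methoxyphenyl, as in a number 1.46 log units higher from compound 2 to compound 3 (beyond the scatter) read backwards, took the number down by a large amount, and pyridin-3-yl carries one hydrogen-bond acceptor in place of the bromine and methyl of compound 3. Within the data shown here, no measured compound bears a pyridin-3-yl or any other aromatic ring with a hetero atom on the amide-type nitrogen, so the size of the step rests on extrapolation.

Compound 4 is therefore expected to fall well below compound 3, by an estimated step of a number 2.45 log units lower from compound 3 to compound 4 (beyond the scatter). The value of compound 4 in this assay is estimated at 3.5, within a range from 2.9 to 4.1.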

Compound 4, distribution coefficient: 2.46
Estimate against measurement, compound 4: 1.04 log units above, outside the stated range (below it).
By their numbers in this assay, from the lowest: compound 4; then compound 2; then compound 1; then compound 3.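

In this assay, pyridin-3-yl on the amide-type nitrogen gives the lowest number of the four compounds, and the exchange for 4-bromo-3-methylphenyl, with a number 3.49 log units lower from compound 3 to compound 4 (beyond the scatter), is the largest step yet seen at this position. Within the data shown here, the new group also stands well under the other two groups, with a number 2.03 log units lower from compound 2 to compound 4 (beyond the scatter) and a number 2.79 log units lower from compound 1 to compound 4 (beyond the scatter), so this position spans a far wider range than the earlier compounds showed, and the one aromatic ring with a hetero atom lies at the bottom of it. The data shown hold no measurement that accounts for the size of these steps.

From the compounds shown here alone, how much of the step from compound 3 goes with the loss of the bromine and the methyl, and how much with the ring nitrogen, stays open, and a plain phenyl group on the amide-type nitrogen would separate the two. Going by these compounds, whether the number depends on where the ring nitrogen sits also stays open, a question that pyridin-2-yl and pyridin-4-yl on the same nitrogen would address.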